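A few compounds are considered here, and "the series" means these few. Any claim that something is new, unique, unknown or untested is made for them only; others in the source may bear on it.

Within the data shown here, the account begins with the one number in hand. In an ADME assay on L02 cells (Homo sapiens) for antiproliferative activity, read by CCK-8 assay, with a stated time of 6 days (on this read-out lower numbers stand for stronger inhibition and higher numbers for weaker inhibition), compound 1, whose structure is `N#Cc1ccc(N2CCCc3c(-c4cccnc4)cccc32)cc1C(F)(F)F`, gives 10500 nM, a weak effect on these cells. Compound 2, with structure `CCN(c1ccc(C#N)c(Cl)c1)c1cc(-c2cncnc2)ccc1C`, shares the aryl-amine arrangement with compound 1 but carries a different substitution pattern, and for compound 2 the result in this assay is "not determined" (no result reported), so it stands nowhere on the numbers shown: there is no value for it in this assay, and the gap between it and compound 1 cannot be stated.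

The step to compound 3, `CCN(c1ccc(C#N)c(Cl)c1)c1cc(-c2c[nH]nc2C)ccc1C`, is a single exchange at one position: 3-methyl-1H-pyrazol-4-yl in place of pyrimidin-5-yl on an aromatic carbon. Among the measured compounds shown here, no measured pair in this set covers such an exchange, so the expectation for the size of the step in this assay rests on the weak activity of compound 1 alone; the change from compound 2 to compound 3 is expected to be small, within the scatter of repeated measurements, with no clear direction. Compound 3 is accordingly expected to give about 10000 nM in this assay, within a range from 3000 nM to 40000 nM, with a fair chance that only a limit is reported.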

Compound 3, half-maximal inhibitory concentration: 5780 nM
The estimate for compound 3 lay 1.7-fold (0.24 log units) above the measured number; measured number inside the range.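

Compound 2 has no number in this assay, and the step from it to compound 3 therefore cannot be read. The compounds shown leave open how the exchange of pyrimidin-5-yl for 3-methyl-1H-pyrazol-4-yl shifts the read-out on these cells. No supporting evidence bears on the result for compound 3.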